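A few compounds are considered here, and "the series" means these few. Any claim that something is new, unique, unknown or untested is made for them only; others in the source may bear on it.

Compound 1 `CC(C)Nc1nc(NCc2ccco2)c2cccc(Cl)c2n1` gives 67.6 10^-6 cm/s in a physicochemical assay for permeability, using PAMPA, at pH 4; a higher number here means that the compound crosses the layer faster, a lower number that the compound crosses the layer more slowly.
Compound 2 `CC(C)Nc1nc(NCc2ccco2)c2cc(Cl)ccc2n1` gives 170 10^-6 cm/s.
Compound 3 `Cc1cccc2c(NCc3ccco3)nc(NC(C)C)nc12` gives 45.9 10^-6 cm/s.

Compound 1 and compound 2 contain the same atoms joined differently; the difference between the two cores is not broken down here. In this assay compound 2 stands highest of the three. Compound 3 comes from compound 1 by methyl in place of chloro on an aromatic carbon, and that step is a 1.5-fold lower number from compound 1 to compound 3 (0.17 log units; within the scatter). Compound 4 `Cc1ccc2nc(NC(C)C)nc(NCc3ccco3)c2c1` has not yet been measured; it comes from compound 2 by methyl in place of chloro on an aromatic carbon. This is the same kind of change, but the place differs: in compound 3 the group sits ortho to a fused ring and meta to a fused ring, while in compound 4 it sits meta to a fused ring and para to a fused ring. Because the earlier step was a 1.5-fold lower number from compound 1 to compound 3 (0.17 log units; within the scatter), a step of a 1.5-fold lower number from compound 2 to compound 4 (0.17 log units; within the scatter) is expected here. Compound 4 is therefore estimated at 115 10^-6 cm/s, likely between 60 10^-6 cm/s and 230 10^-6 cm/s.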

Compound 4, apparent permeability: 67.2 10^-6 cm/s
Compound 4: middle estimate off by 1.7-fold (0.23 log units), on the high side; the range from low to high includes it.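

Methyl in place of chloro gives a 2.5-fold lower number from compound 2 to compound 4 (0.40 log units; beyond the scatter) in this assay and this is a clear step, whereas the same swap on the other core gives a 1.5-fold lower number from compound 1 to compound 3 (0.17 log units; within the scatter) and cannot be told apart from noise. So in these two pairs, which carry the group at different places on the ring, the step seen on one core did not predict the size of the step on the other. Two pairs cannot show a general rule for this series, and nothing measured here explains the difference between them.

As far as these compounds go, whether the step would change in the same way with an amine or a nitrile in that place remains open. So does how a carboxylic acid there would behave on either core.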